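Series notes: the step from compound 3 to compound 4

The compounds below may be only part of what the source reports. "The series", "measured", "known", "first", "only" and "open" are said of these compounds alone.

Three measured compounds share one core and differ only in the aryl group on a double-bonded chain carbon bound to a double-bonded chain carbon. In a functional assay on SW-620 cells (Homo sapiens) for antiproliferative activity, read by MTT assay, with a stated time of 24 h (a lower number here means a stronger inhibitor, a higher number a weaker inhibitor), compound 1 `COc1ccc(C(=O)/C=C/c2ccsc2)c2c1C=CC(C)(C)O2` reaches only the limit of > 10000 nM. Compound 2 `COc1ccc(C(=O)/C=C/c2ccccn2)c2c1C=CC(C)(C)O2` gives 5000 nM in this assay. Compound 3 `COc1ccc(C(=O)/C=C/c2ccc(Cl)cc2)c2c1C=CC(C)(C)O2` likewise sits at the limit of > 10000 nM, so only a bound is known for it. The measured steps are thin, given the limit of > 10000 nM in this assay, at which 2 of the 3 values shown sit: a step that the two limits leave unreadable from compound 1 to compound 3, while an at least 2.0-fold higher number from compound 2 to compound 3 (0.30 log units; that floor lies within the scatter), and an at least 2.0-fold lower number from compound 1 to compound 2 (0.30 log units; that floor lies within the scatter).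

Compound 4 `COc1ccc(C(=O)/C=C/c2ccc(O)c(Br)c2)c2c1C=CC(C)(C)O2` is not yet measured. It differs from compound 3 by 3-bromo-4-hydroxyphenyl in place of 4-chlorophenyl on a double-bonded chain carbon bound to a double-bonded chain carbon. Within the data shown here, no measured step touches a hydroxyl or a bromine on this ring, so nothing read here points either way beyond the scatter. Compound 4 is therefore expected to stay near the limit, with a number no higher from compound 3 to compound 4 (the limit leaves the size open) as the expected step. The estimate for compound 4 is 10000 nM, expected to fall between 3000 nM and 30000 nM.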

Compound 4, half-maximal inhibitory concentration: > 10000 nM
Compound 4 ended at the assay's limit (the forecaster's own chance of this, stated with the estimate: 60%); the middle value lies on the limit itself.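

In this assay, compound 4 gives > 10000 nM, which is a limit of the assay and not a number. The 3-bromo-4-hydroxyphenyl group, the only group shown at this position with a hydrogen-bond donor, therefore joins thiophen-3-yl and 4-chlorophenyl at the limit, while pyridin-2-yl in compound 2 remains the only group here with a number. The one readable step is an at least 2.0-fold higher number from compound 2 to compound 4 (0.30 log units; that floor lies within the scatter), and the other two steps to compound 4 cannot be read: the limit of > 10000 nM in this assay, at which 3 of the 4 values shown sit.

On these data alone, the hydroxyl and the bromine enter together, so their separate contributions stay open. Also open, as far as these compounds go, is whether an amine or a carboxylic acid on this aryl ring would give a value that can be read in this assay.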